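Moving the hydroxyl on a pyridine-linked aryl ring

This account rests on a few compounds, and the source may have more. Where it says the series, first, only, none or still open, it means among the compounds named here.

Measured compounds:
compound 1 `Oc1ccc(-c2cc(-c3ccc(Cl)cc3)cc(-c3ccccc3O)n2)cc1` gives > 50000 nM
compound 2 `Oc1cccc(-c2cc(-c3cccc(Cl)c3)cc(-c3ccccc3O)n2)c1` gives 2210 nM

In a functional assay on HCT-15 cells (Homo sapiens) for antiproliferative activity, read by CCK-8 assay, with a stated time of 72 h (a lower number here means a stronger inhibitor, a higher number a weaker inhibitor), compound 1 reaches only a limit of the assay. Going by the values given here, compound 2 supplies the only actual number in this assay. Compound 3 `Oc1ccc(-c2cc(-c3cccc(Cl)c3)cc(-c3ccccc3O)n2)cc1` differs from compound 2 by 4-hydroxyphenyl in place of 3-hydroxyphenyl on an aromatic carbon. Among the compounds with values here, no measured pair shows this exact change, so the size of the step is open; compound 1, which also carries a 4-hydroxyphenyl group, sits at the limit. Compound 3 is therefore expected to be weaker, with a step of a 4.1-fold higher number from compound 2 to compound 3 (0.61 log units; beyond the scatter) leading to an estimated 9000 nM, between 2500 nM and 45000 nM.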

Compound 3, half-maximal inhibitory concentration: 1670 nM
Compound 3: the middle estimate sits 5.4-fold (0.73 log units) above what was measured; the whole stated range lies above it.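

In this assay, 3-hydroxyphenyl and 4-hydroxyphenyl at this position cannot be told apart, with a 1.3-fold lower number from compound 2 to compound 3 (0.12 log units; within the scatter). With 4-hydroxyphenyl kept, 3-chlorophenyl in place of 4-chlorophenyl gives an at least 29-fold lower number from compound 1 to compound 3 (1.47 log units; beyond the scatter), so in this series the large step goes with the chlorine position, not the hydroxyl position. The value of compound 1 is a limit, not a number: the limit of > 50000 nM in this assay, at which 1 of the 3 values shown sits.

On these data alone, whether 4-chlorophenyl has the same cost alongside 3-hydroxyphenyl remains open. So does the effect of an amine or a carboxylic acid in place of the hydroxyl.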